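This account rests on a few compounds, and the source may have more. Where it says the series, first, only, none or still open, it means among the compounds named here.

Compound 3 `O=c1[nH]c(=O)n([C@H]2C[C@H](O)[C@@H](CO)O2)cc1C#Cc1ccccc1` has only a limit in an ADME assay on L1210/0 cells (Mus musculus) for cytotoxicity, with a stated time of 48 h; on this read-out lower numbers stand for stronger inhibition and higher numbers for weaker inhibition: it reads > 200000 nM, which is a limit of the assay and not a number. Two relatives give measured numbers there: compound 1 `O=c1[nH]c(=O)n([C@H]2C[C@H](O)[C@@H](CO)O2)cc1CO` at 9180 nM and compound 2 `[N-]=[N+]=NCc1cn([C@H]2C[C@H](O)[C@@H](CO)O2)c(=O)[nH]c1=O` at 124000 nM.

Next in line is compound 4 `C#COc1cn([C@H]2C[C@H](O)[C@@H](CO)O2)c(=O)[nH]c1=O`, with the change ethynyloxy in place of 2-phenylethynyl on an aromatic carbon. The nearest evidence comes from the other replacements on that aromatic carbon. The step of an at least 21-fold higher number from compound 1 to compound 3 (1.33 log units; beyond the scatter) is large and beyond the scatter. The step of an at least 1.6-fold higher number from compound 2 to compound 3 (0.20 log units; that floor lies within the scatter) has a floor within the scatter and sets compound 3 apart from compound 2 less firmly. The step of a 14-fold higher number from compound 1 to compound 2 (1.13 log units; beyond the scatter) is also large, showing that the number moves widely even among compounds without 2-phenylethynyl. No measurement covers ethynyloxy itself, and the size of the change remains uncertain.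

With 2-phenylethynyl gone, a sizeable step towards a lower number is expected in this assay, on the precedent of compound 1 and an at least 21-fold higher number from compound 1 to compound 3 (1.33 log units; beyond the scatter), although a reading at the limit remains possible. The expected change is an at least 3.3-fold lower number from compound 3 to compound 4 (0.52 log units; beyond the scatter). Compound 4 is estimated at 60000 nM, with an expected range of 10000 nM to 200000 nM.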

Compound 4, half-maximal inhibitory concentration: > 200000 nM
Compound 4: only a limit was reported; the forecaster's own chance of this, stated with the estimate: 25%; middle value at least 3.3-fold (0.52 log units) away from the limit.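

Compound 4 reads > 200000 nM in this assay, which is a limit of the assay and not a number, so replacing 2-phenylethynyl with the much smaller ethynyloxy on this aromatic carbon does not bring the read-out back into the measurable range. Against hydroxymethyl the separation is firm, with an at least 21-fold higher number from compound 1 to compound 4 (1.33 log units; beyond the scatter), whereas azidomethyl is set apart less securely, with an at least 1.6-fold higher number from compound 2 to compound 4 (0.20 log units; that floor lies within the scatter). No step between compound 3 and compound 4 can be read, and the size of this change remains unknown: the limit of > 200000 nM in this assay, at which 2 of the 4 values shown sit.

Compound 3 and compound 4 both carry a triple bond outside aromatic rings, and two compounds cannot show whether that feature goes with the limit or whether the loss of the hydroxymethyl group of compound 1 is enough on its own. From the compounds shown here alone, it also remains open whether an aminomethyl group, a carboxylic acid or a longer hydroxyalkyl chain at this position would read nearer to compound 1 at 9180 nM, or whether the number depends on keeping that hydroxy group.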